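From Iodo to Hydroxy on the Pendant Phenyl Ring

The source may hold more compounds than are shown below. What is called first, only, known or untested is meant among the compounds shown, and "the series" means these compounds.

Of the compounds shown here, three built on one shared core have been tested in a functional assay (muscle tissue) with Cavia porcellus as the target; on this read-out higher numbers stand for an effect only at larger amounts of compound and lower numbers for an effect already at smaller amounts. Compound 1 `COC(=O)C1=C(C)N=C(C)/C(=C(\O)OC)C1c1ccc(I)cc1` gives 22900 nM, the highest of the three numbers. Compound 2 `COC(=O)C1=C(C)N=C(C)/C(=C(\O)OC)C1c1ccc(C#N)cc1` gives 3470 nM, and compound 3 `COC(=O)C1=C(C)N=C(C)/C(=C(\O)OC)C1c1cccc([N+](=O)[O-])c1` gives 3.98 nM, far below both. Within the data shown here, the only step between compounds that differ in a single place is a 6.6-fold lower number from compound 1 to compound 2 (0.82 log units; beyond the scatter), which shows that exchanging the iodo group is enough to move the number well beyond the scatter. Compound 3 differs from compound 1 in two places at once, and its value shows only that a phenyl substituted in the 3-position can sit with a much lower number.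

Compound 4 `COC(=O)C1=C(C)N=C(C)/C(=C(\O)OC)C1c1cccc(O)c1` is the next compound to be measured. Its change from compound 1 is 3-hydroxyphenyl in place of 4-iodophenyl on a saturated ring carbon. Among the measured compounds shown here, no measured step covers this exact exchange, so the expectation rests on compound 2, whose step was modest, and on compound 3, whose value lies far lower. A step in this assay toward a lower number is therefore expected, estimated as a 15-fold lower number from compound 1 to compound 4 (1.18 log units; beyond the scatter), with wide uncertainty. Compound 4 is thus expected to give about 1500 nM, likely between 150 nM and 15000 nM.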

Compound 4, half-maximal effective concentration: 1000 nM
The estimate for compound 4 lay 1.5-fold (0.18 log units) above the measured number, and the stated range covers the measured number.
By their numbers in this assay, from the lowest: compound 3; then compound 4; then compound 2; then compound 1.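

Hydroxy in place of nitro on an aromatic carbon gives a 250-fold higher number from compound 3 to compound 4 (2.40 log units; beyond the scatter) in this assay and is the first exchange here that keeps the substituent in the 3-position of the phenyl ring, so placement in the 3-position alone does not bring the very low number of compound 3. Compound 4 still lies beyond the scatter from both compounds with a 4-substituted phenyl: 3-hydroxyphenyl in place of 4-iodophenyl gives a 23-fold lower number from compound 1 to compound 4 (1.36 log units; beyond the scatter) on the shared core, and 3-hydroxyphenyl in place of 4-cyanophenyl gives a 3.5-fold lower number from compound 2 to compound 4 (0.54 log units; beyond the scatter) on that same core. Nothing available here explains why these numbers differ.

Both of those last two steps change the group and its place on the phenyl ring together, so the compounds shown cannot say how much of each step belongs to the group and how much to its place, and a pair such as 3-iodophenyl and 4-iodophenyl would be needed to separate the two. As far as these compounds go, how other groups in the 3-position, such as an amine, a carboxylic acid or a methoxy group, would compare with hydroxy and nitro also remains open.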